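Cytotoxicity notes on a small chalcone-free series of enone compounds

A few compounds are considered here, and "the series" means these few. Any claim that something is new, unique, unknown or untested is made for them only; others in the source may bear on it.

Measured compounds:
- compound 1, `COc1ccc(/C=C/C(=O)c2c(O)cc(O)cc2OC)cc1`: "not determined" (no result reported) in an ADME assay on Vero cells (Chlorocebus sabaeus) for cytotoxicity, read by MTT assay; on this read-out lower numbers stand for stronger inhibition and higher numbers for weaker inhibition
- compound 2, `C=CCOc1cc(OC)c(C(=O)/C=C/c2ccccn2)c(OCC=C)c1`: 2800 nM

Compound 1 carries no number in this assay, so compound 2 is the only point of reference. In this assay, for the measured compounds named here, compound 2 gives 2800 nM, the sole value shown, and nothing can yet be said about how it stands against any other member of the series.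

Compound 3, `C=CCOc1cc(OC)c(C(=O)/C=C/c2ccc(Cl)cc2)c(OCC=C)c1`, is not yet measured. It differs from compound 2 in one place: 4-chlorophenyl in place of pyridin-2-yl on a double-bonded chain carbon bound to a double-bonded chain carbon. Going by the values given here, no measured pair shows what this kind of change does here, so the size of the step cannot be read from the data. The expectation is for a step from compound 2 to compound 3 of about a 1.4-fold lower number from compound 2 to compound 3 (0.15 log units; within the scatter), within the usual scatter or a little towards stronger inhibition. Compound 3 is therefore estimated at 2000 nM, with a range from 600 nM to 7000 nM.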

Compound 3, half-maximal inhibitory concentration: 10400 nM
Beside the measured number, compound 3's estimate is 5.2-fold (0.72 log units) below it; the whole stated range lies below it.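

In this assay the position on a double-bonded chain carbon bound to a double-bonded chain carbon responds to the group it carries: 4-chlorophenyl in place of pyridin-2-yl gives a 3.7-fold higher number from compound 2 to compound 3 (0.57 log units; beyond the scatter) and moves the read-out towards weaker inhibition. For the compounds shown here, this is the first readable step, and it rests on a single pair, so it gives a direction for this one change and no general trend for the position. Nothing available bears on why the number moves this way.

Open, going by these compounds, is whether the shift follows from losing the ring nitrogen or from gaining the chlorine, which plain phenyl would help separate. Also open, on these data alone, is how the position would respond to a ring carrying an amine or a carboxylic acid.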